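A single methyl on the chain of compound 2

The source may report more compounds than this note shows. Statements on the series, on what has been measured and on what is new or still open speak of the compounds shown alone.

In an ADME assay on MT4 cells (Homo sapiens) for cytotoxicity, read by MTT assay (a higher number here means that more compound is tolerated, a lower number that less compound is tolerated), compound 2 (`Cc1cc(C)cc(S(=O)(=O)c2c(C(=O)NCC(=O)NCc3ccccc3F)[nH]c3ccc(Cl)cc23)c1`) gives > 47300 nM as a limit and not as a number. Compound 1 (`Cc1cc(C)cc(S(=O)(=O)c2c(C(=O)NC(C)c3ccco3)[nH]c3ccc(Cl)cc23)c1`) gives > 54700 nM in this assay and this too is a limit. Compound 3 (`Cc1cc(C)cc(S(=O)(=O)c2c(C(=O)NC(C)C(=O)NCc3ccccc3F)[nH]c3ccc(Cl)cc23)c1`) differs from compound 2 in one place, a methyl in place of hydrogen on a saturated chain carbon bound to an amide-type nitrogen and a carbonyl carbon. Among the measured compounds shown here, only one measured step bears on it, a step that the two limits leave unreadable from compound 1 to compound 2, and its size cannot be read. That step also changes a different stretch of the molecule. No shift beyond the scatter is therefore expected in this assay, and no direction can be given. The expected move is a number no higher from compound 2 to compound 3 (the limit leaves the size open) and no more. For compound 3 the estimate is 47000 nM with an expected range from 20000 nM to 90000 nM and the result will most likely be a limit again.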

Compound 3, half-maximal cytotoxic concentration: 23300 nM
Beside the measured number, compound 3's estimate is 2.0-fold (0.30 log units) above it; measured number inside the range.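

Among the compounds shown here, the methyl on the saturated chain carbon bound to an amide-type nitrogen and a carbonyl carbon gives compound 3 a measured number in this assay, the only one of the three compounds not reported as a limit, and the step reads as an at least 2.0-fold lower number from compound 2 to compound 3 (0.30 log units; that floor lies within the scatter). The change at the chain carbon bound to an amide-type nitrogen and a saturated chain carbon reads as an at least 2.3-fold lower number from compound 1 to compound 3 (0.37 log units; beyond the scatter), so here the floor itself clears the scatter. Compound 2 stands at a limit, so the methyl step is known only as a floor: the limit of > 47300 nM in this assay, at which 1 of the 3 values shown sits.

The compounds shown leave open how far the number would move with an ethyl or a longer chain on this carbon. They also leave open whether a hydroxymethyl or an amine there would give a number or a limit again.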